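Ethynyl in Place of Bromo on the Nonanamide Core

The compounds below may be only part of what the source reports. "The series", "measured", "known", "first", "only" and "open" are said of these compounds alone.

Compound 3 `CCCCCCCCC(=O)NCc1cc(Br)c(O)c(OC)c1` gives 252 nM in an assay on HEK293 cells for inhibition of transient receptor potential cation channel subfamily V member 1 (Homo sapiens) (a higher number here means a weaker inhibitor, a lower number a stronger inhibitor), the highest of the three numbers seen so far. Compound 1 `CCCCCCCCC(=O)NCc1cc(I)c(O)c(OC)c1` gives 126 nM, and a 2.0-fold higher number from compound 1 to compound 3 (0.30 log units; within the scatter) stays within the scatter. Compound 2 `CCCCCCCCC(=O)NCc1cc(OC)c(O)cc1Cl` gives 50.3 nM, a gap to compound 3 that lies beyond the scatter. Compound 4 `C#Cc1cc(CNC(=O)CCCCCCCC)cc(OC)c1O` differs from compound 3 by ethynyl in place of bromo on an aromatic carbon, ortho to the hydroxy group and meta to the methoxy group. Among the measured compounds shown here, the only measured step at this position is the halogen swap from compound 1 to compound 3, which stayed within the scatter; no step with ethynyl exists. Compound 4 is therefore expected to give 200 nM, between 60 nM and 700 nM, an expected step of a 1.3-fold lower number from compound 3 to compound 4 (0.10 log units; within the scatter) from compound 3.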

Compound 4, half-maximal inhibitory concentration: 2740 nM
The estimate for compound 4 lay 14-fold (1.14 log units) below the measured number, and the stated range ends below it.
By their numbers in this assay, from the lowest: compound 2; then compounds 1 and 3 (each within the scatter of the next); then compound 4.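

In this assay the two halogens on this aromatic carbon, ortho to a hydroxy group, stayed within the scatter of each other, with a 2.0-fold higher number from compound 1 to compound 3 (0.30 log units; within the scatter). Ethynyl breaks that pattern, giving an 11-fold higher number from compound 3 to compound 4 (1.04 log units; beyond the scatter) and a 22-fold higher number from compound 1 to compound 4 (1.34 log units; beyond the scatter). This position is therefore not indifferent to what it carries, though nothing measured here accounts for the large steps. From the compounds shown here alone, whether an amine or a nitrile on the same carbon would stay with the halogens or follow ethynyl remains open. So does whether the ethynyl step would persist with a longer chain on the amide.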